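Toward a Smaller Saturated Ring on the Shared Core

The compounds below may be only part of what the source reports. "The series", "measured", "known", "first", "only" and "open" are said of these compounds alone.

Compound 2 `COc1cccc(Cc2cnc(CCc3ccc(-c4ccccc4C(=O)O)cc3)[nH]2)c1` gives 79 nM in an in vitro functional assay on cells for agonist activity at Bombesin receptor subtype-3 (Mus musculus), read by luminescence and calcium flux (on this read-out higher numbers stand for an effect only at larger amounts of compound and lower numbers for an effect already at smaller amounts), the highest of the two numbers seen so far; compound 1 `O=C(O)c1ccccc1-c1ccc(CCc2ncc(CCC3CCCCC3)[nH]2)cc1` gives 33 nM. Within the data shown here, the one measured step, a 2.4-fold higher number from compound 1 to compound 2 (0.38 log units; beyond the scatter), bears directly on the present change, since compound 3 `O=C(O)c1ccccc1-c1ccc(CCc2ncc(CC3CCCC3)[nH]2)cc1` carries cyclopentyl in place of 3-methoxyphenyl on a saturated chain carbon bound to an aromatic carbon, returning to a saturated ring of carbon only, as in compound 1. He therefore expects the number to move back down, with a step of a 1.8-fold lower number from compound 2 to compound 3 (0.24 log units; within the scatter) in this assay. His estimate for compound 3 is 45 nM, within a range of 15 nM to 140 nM.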

Compound 3, half-maximal effective concentration: 7.9 nM
Estimate against measurement, compound 3: 5.7-fold (0.76 log units) above; measured number outside the range, below it.
By their numbers in this assay, from the lowest: compound 3; then compound 1; then compound 2.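

In this assay, cyclopentyl in place of 3-methoxyphenyl on a saturated chain carbon bound to an aromatic carbon gives a 10-fold lower number from compound 2 to compound 3 (1.00 log units; beyond the scatter), a far larger move at this position than the earlier step showed. Cyclopentyl in place of cyclohexylmethyl gives a 4.2-fold lower number from compound 1 to compound 3 (0.62 log units; beyond the scatter), so the two saturated groups are also set apart here. No measurement offered accounts for either step.

The second step alters ring size and chain length together, leaving their separate shares open. Cyclohexyl at the same place would divide them, while an amine-bearing ring would test whether a ring of carbon only is needed.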